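Swapping chloro for fluoro on the phenoxy arm

A few compounds are considered here, and "the series" means these few. Any claim that something is new, unique, unknown or untested is made for them only; others in the source may bear on it.

Of the compounds shown here, two built on one shared core have been tested in a functional assay on the whole organism (strain NMRI) with Mus musculus as the target, with a stated time of 60 min, at a dose of 10 mg/kg by the intraperitoneal route; a lower number here means a weaker effect, a higher number a stronger effect of the compound at the dose given. Compound 1 `CSc1nnc(Cc2ccc(Cl)cc2Oc2ccccc2F)[nH]1` carries a 2-fluorophenoxy group, and in this assay compound 1 gives 121%. Compound 2 `CCOc1nnc(Cc2ccc(Cl)cc2Oc2ccccc2Cl)[nH]1` carries a 2-chlorophenoxy group instead, together with a different substituent on the core, and in this assay compound 2 gives 122%. Of the two numbers, that of compound 2 is the larger, but only by a margin within the scatter, so the two readings count as alike. Compound 3 `CCOc1nnc(Cc2ccc(Cl)cc2Oc2ccccc2F)[nH]1` is compound 2 with a single change: fluoro in place of chloro on an aromatic carbon. For the measured compounds named here, no measured pair differing in this way alone exists, so the size of such a step is not known from direct data. Compound 1 and compound 2 differ in two places, one of them this same chloro-to-fluoro exchange, yet they read alike, which gives no hint of a large effect. The step from compound 2 to compound 3 is therefore expected to be small, a number 2 percentage points lower from compound 2 to compound 3 (within the scatter), no more than the scatter. Compound 3 is expected to give 120% in this assay, with a range from 100% to 140%.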

Compound 3, a percentage reported as activity, at one dose (the size of the read-out at that dose, not a potency): 116%
Estimate against measurement, compound 3: 4 percentage points above; the range from low to high includes it.
By their numbers in this assay, from the lowest: compounds 3, 1 and 2 (each within the scatter of the next).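

In this assay the exchange of 2-chlorophenoxy for 2-fluorophenoxy now has a direct reading: the step is a number 6 percentage points lower from compound 2 to compound 3 (within the scatter) and shows that chloro and fluoro cannot be told apart at this place, on an aromatic carbon ortho to a large group, at the dose given. The change at the other place, ethoxy in place of methylsulfanyl on an aromatic carbon, reads a number 5 percentage points lower from compound 1 to compound 3 (within the scatter) and is equally unable to separate the two compounds, so neither single exchange shifts the read-out measurably. No separate measurement bears on these readings, and nothing here accounts for how little they differ.

As far as these compounds go, all three compounds carry ethoxy or methylsulfanyl on the core and chloro or fluoro on the phenoxy arm, so it remains open whether an amine or a longer chain on the core, or a methoxy group or a nitrile in place of the halogen, would keep the same reading. From the compounds shown here alone, each number is also the size of an effect at one dose, so how these compounds would compare at other doses remains open too.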